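The compounds below may be only part of what the source reports. "The series", "measured", "known", "first", "only" and "open" are said of these compounds alone.

Compound 2 `CCOC(=O)c1cc2ccc(OCCCn3cc(CNC(=O)CCCCC4CCSS4)nn3)cc2oc1=O` gives 28.3% in a functional assay on PC-12 cells (Rattus norvegicus) for cytotoxicity, read by MTT assay, with stated times of 3 h and 2 h, tested at 1 uM; on this read-out higher numbers stand for a stronger effect at the one concentration tested and lower numbers for a weaker effect. Compound 1 `CC(=O)c1cc2ccc(OCCCn3cc(CNC(=O)CCCCC4CCSS4)nn3)cc2oc1=O` gives 35.5% in this assay, and the two numbers lie within the scatter of each other, as a number 7.2 percentage points lower from compound 1 to compound 2 (within the scatter) shows. Compound 3 `O=C(CCCCC1CCSS1)NCc1cn(CCCOc2ccc3cc(C(=O)O)c(=O)oc3c2)nn1` is not yet measured; the change is hydrogen in place of ethyl on an oxygen next to a carbonyl group. Going by the values given here, no measured step alters the same oxygen; the only step on the neighbouring carbonyl carbon, a number 7.2 percentage points lower from compound 1 to compound 2 (within the scatter), was within the scatter. Compound 3 is therefore expected to give 28% (range 14% to 42%), and the step of a number 0.3 percentage points lower from compound 2 to compound 3 (within the scatter) is expected to stay within the scatter.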

Compound 3, a percentage reported as activity, at one concentration (the size of the read-out at that concentration, not a potency): 52.1%
For compound 3 the middle estimate is 24.1 percentage points below the measured one; the measured number lies above the stated range.
By their numbers in this assay, from the lowest: compounds 2 and 1 (each within the scatter of the next); then compound 3.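

Hydrogen in place of ethyl on this oxygen gives a step beyond the scatter in this assay (a number 23.8 percentage points higher from compound 2 to compound 3 (beyond the scatter)), so this position does respond to change, which the comparison of compound 1 and compound 2 alone did not show. The carboxy compound also stands apart from the methyl compound (a number 16.6 percentage points higher from compound 1 to compound 3 (beyond the scatter)), while methyl and ethoxy remain within the scatter of each other. Nothing available accounts for this step.

On these data alone, whether a primary amide or a methoxy group here would group with compound 3 or with compound 2 remains open. As far as these compounds go, whether the order holds at other concentrations also remains open.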